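A thioether replaces the amine at the limit

A few compounds are considered here, and "the series" means these few. Any claim that something is new, unique, unknown or untested is made for them only; others in the source may bear on it.

- Compound 1 `CC(C)Nc1nc(N)nc2c1ncn2/C=C1/CC1(CO)CO` gives > 20000 nM, a limit of the assay.
- Compound 2 `CC(C)CNc1nc(N)nc2c1ncn2/C=C1/CC1(CO)CO` gives > 20000 nM, a limit of the assay.

In an ADME assay on CCRF-HSB-2 cells (Homo sapiens) for cytotoxicity, with a stated time of 7 days (on this read-out higher numbers stand for lower toxicity in this test and lower numbers for higher toxicity in this test), compound 2 gives > 20000 nM, which is a limit and not a number. The evidence so far is the limit of > 20000 nM in this assay, at which 2 of the 2 values shown sit. For the measured compounds named here, the one measured step, a step that the two limits leave unreadable from compound 1 to compound 2, offers no size to carry forward. In compound 3 `CCCCSc1nc(N)nc2c1ncn2/C=C1/CC1(CO)CO`, butylsulfanyl takes the place of isobutylamino on an aromatic carbon (butylsulfanyl in place of isobutylamino on an aromatic carbon). Going by the values given here, no measured step covers this exchange, so no change beyond the scatter is the working expectation, with a readable shift possible only towards higher toxicity. The expected step is a number no higher from compound 2 to compound 3 (the limit leaves the size open). Compound 3 is expected at 20000 nM, within an estimated range of 7000 nM to 50000 nM.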

Compound 3, half-maximal cytotoxic concentration: 89000 nM
Beside the measured number, compound 3's estimate is 4.5-fold (0.65 log units) below it; the measured number lies above the stated range.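

The values of compound 1 and compound 2 are limits and not numbers, and neither step to compound 3 can be read. The compounds shown leave open how far butylsulfanyl in place of isobutylamino or isopropylamino moves this read-out.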